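The source may report more compounds than this note shows. Statements on the series, on what has been measured and on what is new or still open speak of the compounds shown alone.

Compound 1 `Cc1ccccc1-c1noc(-c2ccc(C3CCCCC3)cc2)n1` gives > 10000 nM in a functional assay on CHO cells with sphingosine 1-phosphate receptor 2 (Homo sapiens) as the target, read by GTPgammaS binding; on this read-out higher numbers stand for an effect only at larger amounts of compound and lower numbers for an effect already at smaller amounts; this is a limit.
Compound 2 `Cc1cc(CCC(=O)O)ccc1-c1noc(-c2ccc(OC(C)C)c(C(F)(F)F)c2)n1` gives > 10000 nM in this assay; this is a limit.
Compound 3 `Cc1cc(CCC(=O)O)ccc1-c1noc(-c2ccc(OC(C)C)c(F)c2)n1` gives > 10000 nM in this assay; this is a limit.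

Compound 3 thus stands at the limit of this assay, as the limit of > 10000 nM in this assay, at which 3 of the 3 values shown sit, shows, and the step that the two limits leave unreadable from compound 2 to compound 3 cannot be read. Compound 4 `Cc1cc(CCC(=O)O)ccc1-c1noc(-c2ccc(OC(C)C)c(Cl)c2)n1` differs from compound 3 by chloro in place of fluoro on an aromatic carbon. Within the data shown here, the only measured step that bears on this position is the one from compound 2 to compound 3, and its size is unreadable, so the data give no direction for the step in this assay. With all three values at the limit, compound 4 is expected to remain there too, a step that the limit leaves unreadable from compound 3 to compound 4. The estimate for compound 4 in this assay is 15000 nM, in the range 4000 nM to 60000 nM.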

Compound 4, half-maximal effective concentration: > 10000 nM
Compound 4: no number, only a limit; the forecaster's own chance of this, stated with the estimate: 85%; the middle value is on the limit's open side.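

The steps from compound 2 and from compound 3 to compound 4 cannot be read in this assay. The compounds shown leave open whether changing the group on that aromatic carbon alters the read-out in this assay at all.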